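A few compounds are considered here, and "the series" means these few. Any claim that something is new, unique, unknown or untested is made for them only; others in the source may bear on it.

Three glycolipids were measured in a functional assay on U-373MG ATCC cells (Homo sapiens), read by thymidine incorporation; a higher number here means a weaker inhibitor, a lower number a stronger inhibitor. Compound 1 `CCCCCCCC/C=C\CCCCCCCCO[C@H]1O[C@H](CO)[C@@H](O)[C@H](O)[C@H]1NC(C)=O` gives 4.6 uM in this assay. Compound 3 `CCCCCCCCCCCCCCCCO[C@H]1O[C@H](COCC(CO)(CO)CO)[C@@H](O)[C@H](O)[C@H]1NC(=O)CCCC` gives 27.3 uM, and compound 2 `CCCCCCCCCCCCCCCCO[C@H]1O[C@H](COCC(CO)(CO)COS(=O)(=O)O)[C@@H](O)[C@H](O)[C@H]1NC(=O)CCCC` gives 3.2 uM. Compound 2 carries one change relative to compound 3, (sulfo in place of hydrogen on an oxygen on a saturated carbon), and this change produced an 8.5-fold lower number from compound 3 to compound 2 (0.93 log units; beyond the scatter). The difference between the core of compound 1 and the core of compound 3 is not broken down here. Compound 4 `CCCCCCCC/C=C\CCCCCCCCO[C@H]1O[C@H](COS(=O)(=O)O)[C@@H](O)[C@H](O)[C@H]1NC(C)=O` carries the same change relative to compound 1, (sulfo in place of hydrogen on an oxygen on a saturated carbon), at a place described in the same words. Because the earlier step gave an 8.5-fold lower number from compound 3 to compound 2 (0.93 log units; beyond the scatter), the step from compound 1 to compound 4 is expected to be a 5.8-fold lower number from compound 1 to compound 4 (0.76 log units; beyond the scatter), with some allowance for the different core. Compound 4 is therefore estimated to give 0.8 uM, expected between 0.3 uM and 2.5 uM.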

Compound 4, concentration for 50% inhibition: 13 uM
For compound 4 the middle estimate is 16-fold (1.21 log units) below the measured one, and the stated range ends below it.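

In this assay, sulfo in place of hydrogen on an oxygen on a saturated carbon did not carry over from one core to the other, giving a 2.8-fold higher number from compound 1 to compound 4 (0.45 log units; beyond the scatter). The two steps run in opposite directions, so in this series the outcome of this change depends on the core that carries it: the same change on two cores in this assay, an 8.5-fold lower number (0.93 log units; beyond the scatter) from compound 3 to compound 2 and a 2.8-fold higher number (0.45 log units; beyond the scatter) from compound 1 to compound 4, 24-fold (1.38 log units) apart, beyond the scatter of two such steps. Among the compounds shown here, with only two pairs and cores that differ in more than one place, this does not show which difference between the cores decides the direction of the step, nor how the change would behave on any further core.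

From the compounds shown here alone, it remains open whether a phosphate or a carboxylic acid in place of the sulfo group would follow the same split between the two cores.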